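A few compounds are considered here, and "the series" means these few. Any claim that something is new, unique, unknown or untested is made for them only; others in the source may bear on it.

Compounds measured in a functional assay on cells (T-cell, Homo sapiens) for inhibition; a higher number here means a weaker inhibitor, a lower number a stronger inhibitor:
- compound 1, `COc1ccc(-c2cnc3nc(N)nc(N4CCN(C(=O)NCc5ccc(F)cc5)CC4)c3n2)cc1OC`: 37 nM
- compound 2, `COc1ccc(-c2cnc3nc(N)nc(N4CCC(C)CC4)c3n2)cc1OC`: 800 nM
- compound 3, `COc1ccc(-c2cnc3nc(N)nc(NC4CCCC4)c3n2)cc1OC`: 800 nM

Compound 1 has the lowest number of the three; compound 2 and compound 3 both sit well beyond the scatter from it, and their two values are within the scatter of each other. Within the data shown here, the only one-place step measured so far, no change at the digits printed from compound 2 to compound 3 (within the scatter), concerns cyclopentylamino in place of 4-methylpiperidin-1-yl on an aromatic carbon and says nothing about the urea-bearing piperazine of compound 1.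

Compound 4, `COc1ccc(-c2cnc3nc(N)nc(N4CCN(C(=O)Nc5ccc(C)cc5)CC4)c3n2)cc1OC`, differs from compound 1 in one place: 4-methylphenyl in place of 4-fluorobenzyl on an amide-type nitrogen. Among the measured compounds shown here, no measured pair probes this change, so the expectation rests on compound 1 alone. Since the piperazine urea is kept intact, a number of the same order as compound 1 is expected, with the uncertainty spread to both sides. For compound 4 the expected step is a 1.6-fold higher number from compound 1 to compound 4 (0.21 log units; within the scatter). The estimate for compound 4 in this assay is 60 nM, with a range from 15 nM to 250 nM.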

Compound 4, half-maximal inhibitory concentration: 0.8 nM
Compound 4: the middle estimate sits 75-fold (1.88 log units) above what was measured, and the stated range ends above it.
By their numbers in this assay, from the lowest: compound 4; then compound 1; then compounds 2 and 3 (each within the scatter of the next).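

In this assay the group on the amide-type nitrogen turns out to matter a great deal: 4-methylphenyl in place of 4-fluorobenzyl gives a 46-fold lower number from compound 1 to compound 4 (1.67 log units; beyond the scatter). Among these compounds, the earlier compounds varied only the amine on the shared core, so this is the first reading of how much the far end of the urea can move the number. The two groups look alike by the counts, each with one six-membered aromatic ring of carbon only, no hydrogen-bond donors or acceptors and no net charge, and no measurement bears on why the step is so large.

The change removes the methylene link and swaps fluorine for methyl together, and the compounds shown do not separate the two; 4-fluorophenyl and 4-methylbenzyl on the same nitrogen would. From the compounds shown here alone, whether a non-aromatic group such as cyclohexyl would hold the number also remains open.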